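The compounds below may be only part of what the source reports. "The series", "measured", "known", "first", "only" and "open" are said of these compounds alone.

Compound 3 `O=C(CN1CCN(c2cccc(Cl)c2)CC1)N(c1ccccc1)c1ccccc1` was tested in a functional assay on the whole organism (strain Swiss albino) for inhibition, with Mus musculus as the target, with stated times of 30 min, 10 min and 20 min (a lower number here means that less compound is needed, a higher number that more compound is needed for the effect), where compound 3 gives 18 mg/kg. Among the three compounds measured so far, compound 3 stands second highest of the three numbers. Its nearest neighbour is compound 2 `COc1cccc(N2CCN(CC(=O)N(c3ccccc3)c3ccccc3)CC2)c1`, which gives 15.5 mg/kg, and its furthest is compound 1 `O=C(CN1CCN(c2ccccc2)CC1)N(c1ccccc1)c1ccccc1`, which gives 27 mg/kg. Both gaps lie within the scatter: a 1.2-fold higher number from compound 2 to compound 3 (0.06 log units; within the scatter) and a 1.5-fold lower number from compound 1 to compound 3 (0.18 log units; within the scatter). The remaining pair behaves the same way, with a 1.7-fold lower number from compound 1 to compound 2 (0.24 log units; within the scatter).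

Compound 4 `O=C(CN1CCN(c2ccc(F)cc2)CC1)N(c1ccccc1)c1ccccc1` differs from compound 3 in one place: 4-fluorophenyl in place of 3-chlorophenyl on an amine nitrogen in a ring. The measured steps that bear on this change are those that alter the same ring of the shared core, namely a 1.5-fold lower number from compound 1 to compound 3 (0.18 log units; within the scatter), a 1.7-fold lower number from compound 1 to compound 2 (0.24 log units; within the scatter) and a 1.2-fold higher number from compound 2 to compound 3 (0.06 log units; within the scatter), each of them within the scatter. Nothing measured here points to a step beyond the scatter for exchanging one ring substituent for another in this assay. Compound 4 is therefore expected to give about 20 mg/kg, with a range from 10 mg/kg to 40 mg/kg. That estimate means an expected step of a 1.1-fold higher number from compound 3 to compound 4 (0.05 log units; within the scatter), which is no change beyond the scatter.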

Compound 4, dose for half-maximal effect: 20 mg/kg
For compound 4 middle estimate and measured number coincide at the digits printed; measured number inside the range.
By their numbers in this assay, from the lowest: compounds 2, 3, 4 and 1 (each within the scatter of the next).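

For the compounds shown here, on the aromatic ring carried by the amine nitrogen, the earlier compounds showed only hydrogen, 3-chloro and 3-methoxy, whereas 4-fluorophenyl brings a different halogen at a different ring carbon. Even so, the steps in this assay stay small: a 1.1-fold higher number from compound 3 to compound 4 (0.05 log units; within the scatter), a 1.3-fold higher number from compound 2 to compound 4 (0.11 log units; within the scatter) and, against the plain phenyl of the shared core, a 1.4-fold lower number from compound 1 to compound 4 (0.13 log units; within the scatter). Across these four compounds, then, no exchange at this position gives a step beyond the scatter, whether the group is chloro, methoxy or fluoro, and no measurement is at hand that would explain this flat picture.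

On these data alone, the change from 3-chlorophenyl to 4-fluorophenyl alters the halogen and its place on the ring at once, so the effect of each alone stays unknown, and 4-chlorophenyl or 3-fluorophenyl would be needed to separate them. Also open, as far as these compounds go, is whether a group of another kind on this ring, such as an amine or a carboxylic acid, would give a step beyond the scatter in this assay.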